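Swapping an Ether Side Chain for a Cyclopentyl Thioether

A few compounds are considered here, and "the series" means these few. Any claim that something is new, unique, unknown or untested is made for them only; others in the source may bear on it.

Compound 1 `COCCOc1nc(N)nc2c1ncn2/C=C1/CC1(CO)CO`: in an ADME assay on MOLT-3 cells (Homo sapiens) for cytotoxicity, with a stated time of 7 days (a lower number here means that less compound is tolerated, a higher number that more compound is tolerated), compound 1 gives only a limit of the assay, > 20000 nM.
Compound 2 `Nc1nc(NC2CCCC2)c2ncn(/C=C3/CC3(CO)CO)c2n1`: compound 2 likewise gives only a limit, > 20000 nM.

Within the data shown here, compound 1 therefore stands at the assay limit rather than at a number, and the one other value shown is also a limit. The unmeasured compound 3 `Nc1nc(SC2CCCC2)c2ncn(/C=C3/CC3(CO)CO)c2n1` differs from compound 1 by cyclopentylsulfanyl in place of 2-methoxyethoxy on an aromatic carbon. Among the measured compounds shown here, the only measured step that touches this position is a step that the two limits leave unreadable from compound 1 to compound 2, and because both ends sit at the limit of > 20000 nM in this assay, at which 2 of the 2 values shown sit, its size cannot be read. With nothing readable to draw on, the step from compound 1 to compound 3 is expected to stay within the scatter and most likely to end again at the limit; the expected step is a step that the limit leaves unreadable from compound 1 to compound 3. Compound 3 is thus estimated at 30000 nM, in the range 15000 nM to 80000 nM.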

Compound 3, half-maximal cytotoxic concentration: > 20000 nM
Compound 3 was reported as a limit (the forecaster's own chance of this, stated with the estimate: 85%); the middle value is on the limit's open side.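

No step can be read between compound 1, compound 2 and compound 3, because all three stop at the same assay limit rather than at a number: the limit of > 20000 nM in this assay, at which 3 of the 3 values shown sit.

The compounds shown leave open whether exchanging 2-methoxyethoxy, cyclopentylamino and cyclopentylsulfanyl changes the half-maximal cytotoxic concentration in this assay at all.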